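The compounds below may be only part of what the source reports. "The series", "measured", "known", "first", "only" and "open" are said of these compounds alone.

Compound 2 `COc1cc(/C=C/C(=O)O)cc(OC)c1OC(=O)c1nc(C)c(C)nc1C` gives 96.6% in a functional assay on EA.hy 926 cells (Homo sapiens) for cytotoxicity, read by MTT assay, with stated times of 24 h and 12 h, tested at 50 uM; a lower number here means a weaker effect, a higher number a stronger effect of the compound at the concentration tested. Compound 1 `COc1cc(/C=C/C(=O)O)ccc1OC(=O)c1nc(C)c(C)nc1C` gives 49.1% in this assay, and compound 3 `CCOC(=O)/C=C/c1ccc(OC(=O)c2nc(C)c(C)nc2C)c(OC)c1` gives 69.7%. The step of a number 47.5 percentage points lower from compound 2 to compound 1 (beyond the scatter) corresponds to this change: hydrogen in place of methoxy on an aromatic carbon. The step of a number 20.6 percentage points higher from compound 1 to compound 3 (beyond the scatter) is the other measured one. How the core of compound 3 differs from that of compound 2 is not broken down here. Compound 4 `CCOC(=O)/C=C/c1ccc(OC(=O)c2nc(C)c(C)nc2C)cc1` is not yet measured; it differs from compound 3 by hydrogen in place of methoxy on an aromatic carbon. This is the same kind of change as the earlier one, though the surroundings differ: there the place was also meta to a methoxy group, here it is meta to a 2-(ethoxycarbonyl)ethenyl group. The step from compound 3 to compound 4 is expected to be a number 34.7 percentage points lower from compound 3 to compound 4 (beyond the scatter), a drop like the earlier one but judged smaller because compound 3 starts from 69.7%. Compound 4 is estimated at 35%, between 15% and 60%.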

Compound 4, a percentage reported as activity, at one concentration (the size of the read-out at that concentration, not a potency): 62.6%
Beside the measured number, compound 4's estimate is 27.6 percentage points below it, outside the stated range (above it).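

In this assay, hydrogen in place of methoxy now gives a number 7.1 percentage points lower from compound 3 to compound 4 (within the scatter), so the large drop seen on the other core does not reappear here. The change therefore does not carry over with a fixed size from one core to another in this series: the same change on two cores in this assay, a number 47.5 percentage points lower (beyond the scatter) from compound 2 to compound 1 and a number 7.1 percentage points lower (within the scatter) from compound 3 to compound 4, 40.4 percentage points apart, beyond the scatter of two such steps

This does not show which feature of the cores sets the size of the step, and two pairs give no rule for predicting it on a third core. The compounds shown leave open how a hydroxy group or a fluorine in place of the methoxy would read in this assay. They also leave open whether an amide or a longer chain in place of the ethoxy of the 2-(ethoxycarbonyl)ethenyl group would alter the step.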